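Acetyl in place of hydrogen on the aromatic-ring nitrogen

The compounds below may be only part of what the source reports. "The series", "measured", "known", "first", "only" and "open" are said of these compounds alone.

Measured so far in a functional assay on A375P cells (Homo sapiens) for antiproliferative activity, read by MTT assay, with a stated time of 48 h; on this read-out lower numbers stand for stronger inhibition and higher numbers for weaker inhibition:
compound 1, `Nc1cccc2c(-c3cccc(NC(=O)c4ccc5c(c4)OCCO5)c3)ccnc12`, gives 860 nM.
compound 2, `CC(=O)Nc1cccc2c(-c3cccc(NC(=O)c4ccc5c(c4)OCCO5)c3)ccnc12`, gives 570 nM.
compound 3, `Nc1cccc2c(-c3cccc(NC(=O)Nc4cc(C(F)(F)F)cc(C(F)(F)F)c4)c3)ccnc12`, gives 1400 nM.

Compounds 1 and 2 differ in one place, (acetyl in place of hydrogen on a nitrogen on an aromatic ring). The step in this assay is a 1.5-fold lower number from compound 1 to compound 2 (0.18 log units; within the scatter), so the two numbers sit together within the usual scatter and no direction can be read from them.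

Compound 3 carries the other amide-side group. How its core differs from that of compound 1 is not broken down here. Against compound 1 its number lies within the scatter; against compound 2 it is beyond the scatter, compound 3 giving the higher number of the two.

Compound 4, `CC(=O)Nc1cccc2c(-c3cccc(NC(=O)Nc4cc(C(F)(F)F)cc(C(F)(F)F)c4)c3)ccnc12`, is not yet measured. It differs from compound 3 by acetyl in place of hydrogen on a nitrogen on an aromatic ring. The place matches that of the change from compound 1 to compound 2 word for word, so this is the same change made on the core of compound 3.

For the measured compounds named here, only one measured pair shows this change, and there it stays within the scatter. Going by the values given here, the step from compound 3 to compound 4 in this assay is therefore expected to be about a 1.4-fold lower number from compound 3 to compound 4 (0.15 log units; within the scatter), resting on the step of a 1.5-fold lower number from compound 1 to compound 2 (0.18 log units; within the scatter), with no second pair to confirm it. Compound 4 is expected to give about 1000 nM, most likely between 400 nM and 2500 nM.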

Compound 4, half-maximal inhibitory concentration: 4400 nM
Compound 4: the middle estimate sits 4.4-fold (0.64 log units) below what was measured, outside the stated range (above it).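

In this assay, the same exchange of hydrogen for acetyl on the aromatic-ring nitrogen, read as amino to acetamido, now gives a 3.1-fold higher number from compound 3 to compound 4 (0.50 log units; beyond the scatter), and this step does not match the earlier one: the same change on two cores in this assay, a 1.5-fold lower number (0.18 log units; within the scatter) from compound 1 to compound 2 and a 3.1-fold higher number (0.50 log units; beyond the scatter) from compound 3 to compound 4, 4.7-fold (0.68 log units) apart, beyond the scatter of two such steps

The effect of this change therefore does not carry from the core of compound 1 to the core of compound 3 in this series, and the earlier pair is a poor guide to the later one. On the core of compound 3 the acetyl group goes with weaker inhibition, while on the core of compound 1 no direction can be read. The two pairs do not show which part of the cores sets the difference, since the two cores are not separated into single changes, and two pairs give no rule for any further core.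

Still open, as far as these compounds go, is how a propanoyl group, a methanesulfonyl group or a simple methyl on the same aromatic-ring nitrogen would behave on each of the two cores. Also open, from the compounds shown here alone, is whether a single trifluoromethyl on the terminal ring, or a chlorine in its place, would bring the acetyl step closer to that on the core of compound 1.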